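Pyridinyl for Nitrophenyl in Two Related Cores

The source may hold more compounds than are shown below. What is called first, only, known or untested is meant among the compounds shown, and "the series" means these compounds.

Compound 1 `CO[C@@H]1CC=C2NN(c3ccc([N+](=O)[O-])cc3)C(=O)CC[C@]2(c2ccccc2)O1`: 9200 nM
Compound 2 `CO[C@@H]1CC=C2NN(c3ccccn3)C(=O)CC[C@]2(c2ccccc2)O1`: 1290 nM
Compound 3 `CO[C@@H]1CC=C2N(c3ccc([N+](=O)[O-])cc3)C(=O)C[C@]2(c2ccccc2)O1`: 8100 nM

These values come from a functional assay on DU-145 cells (Homo sapiens) for cytotoxicity, read by sulforhodamine B assay, with a stated time of 48 h; a higher number here means a weaker inhibitor, a lower number a stronger inhibitor. Compound 1 and compound 2 share a core and differ by pyridin-2-yl in place of 4-nitrophenyl on an amide-type nitrogen in a ring, which gave a 7.1-fold lower number from compound 1 to compound 2 (0.85 log units; beyond the scatter). Compound 3 has a different core; how the two cores differ is not broken down here. Compound 4 `CO[C@@H]1CC=C2N(c3ccccn3)C(=O)C[C@]2(c2ccccc2)O1` is not yet measured and differs from compound 3 by pyridin-2-yl in place of 4-nitrophenyl on an amide-type nitrogen in a ring. This is the same kind of change, though its surroundings differ: in compound 1 the ring is seven-membered with 2 nitrogen, next to the ring nitrogen, three ring bonds from the fused-ring atom and from the phenyl-bearing atom, while in compound 3 it is five-membered with 1 nitrogen, two ring bonds from each. A step of about a 5.8-fold lower number from compound 3 to compound 4 (0.76 log units; beyond the scatter) is expected for compound 4 because the same change gave a 7.1-fold lower number from compound 1 to compound 2 (0.85 log units; beyond the scatter). Compound 4 is therefore estimated at 1400 nM in this assay, between 500 nM and 4000 nM.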

Compound 4, half-maximal inhibitory concentration: 8300 nM
For compound 4 the middle estimate is 5.9-fold (0.77 log units) below the measured one; measured number outside the range, above it.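

In this assay, putting pyridin-2-yl in place of 4-nitrophenyl gave a 1.0-fold higher number from compound 3 to compound 4 (0.01 log units; within the scatter) and so left the number on the core of compound 3 within the usual scatter, while the same swap had lowered it on the core of compound 1. The two steps do not agree, so in this series the gain from this swap did not carry from one core to the other: the same change on two cores in this assay, a 7.1-fold lower number (0.85 log units; beyond the scatter) from compound 1 to compound 2 and a 1.0-fold higher number (0.01 log units; within the scatter) from compound 3 to compound 4, 7.3-fold (0.86 log units) apart, beyond the scatter of two such steps. With one pair on each core, this does not show which difference between the cores matters, or whether other swaps would behave the same way.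

Going by these compounds, it remains open how a benzyl group or a simple alkyl chain on the same nitrogen would fare on either core. On these data alone, it is also open whether any group at that nitrogen can lower the number on the core of compound 3.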